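From Fluoro to Nitro on an Aromatic Carbon

The source may report more compounds than this note shows. Statements on the series, on what has been measured and on what is new or still open speak of the compounds shown alone.

- compound 1 `Cc1nc(C)c(/C=C/C(=O)/C=C/c2cccc(O)c2)nc1C`: 4300 nM
- compound 2 `COc1cccc(/C=C/C(=O)/C=C/c2nc(C)c(C)nc2C)c1O`: 2850 nM
- compound 3 `Cc1nc(C)c(/C=C/C(=O)/C=C/c2ccc(F)cc2)nc1C`: 5900 nM

These three numbers come from a functional assay on A549 cells (Homo sapiens) for antiproliferative activity, read by MTT assay, with a stated time of 72 h; on this read-out lower numbers stand for stronger inhibition and higher numbers for weaker inhibition. Compound 3, at 5900 nM, stands at the upper end of them. Among the compounds with values here, its one measured step is a 1.4-fold higher number from compound 1 to compound 3 (0.14 log units; within the scatter). Compound 2, at 2850 nM, shows a number lower than that of compound 3 by more than the usual scatter.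

The next molecule, compound 4 `Cc1nc(C)c(/C=C/C(=O)/C=C/c2ccc([N+](=O)[O-])cc2)nc1C`, keeps the rest of compound 3 and changes one group: nitro in place of fluoro on an aromatic carbon, para to a large group. nitro in place of fluoro on an aromatic carbon

Within the data shown here, no measured compound here carries nitro, so the data give no direct guide to this swap and no clear direction. Among the measured compounds shown here, the only evidence comes from a change of groups on the same ring, a 1.4-fold higher number from compound 1 to compound 3 (0.14 log units; within the scatter), and that step stayed small. On that basis, no step beyond the scatter is expected in this assay, though the uncertainty is wide. The expected step is a 1.3-fold lower number from compound 3 to compound 4 (0.12 log units; within the scatter). The estimated value for compound 4 is 4500 nM, with an expected range from 1800 nM to 11000 nM.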

Compound 4, half-maximal inhibitory concentration: 9600 nM
For compound 4 the middle estimate is 2.1-fold (0.33 log units) below the measured one; the measured number falls inside the stated range.
By their numbers in this assay, from the lowest: compounds 2, 1, 3 and 4 (each within the scatter of the next, the first and the last beyond it).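

In this assay, the place on the aromatic ring that holds fluoro in compound 3 also accepts nitro, and the swap amounts to a 1.6-fold higher number from compound 3 to compound 4 (0.21 log units; within the scatter) with the rest of the molecule unchanged. Fluoro brings one heavy atom and no hydrogen-bond acceptors, while nitro brings three heavy atoms and two hydrogen-bond acceptors, so a clearly larger group at this place still leaves the number within the usual spread of repeat measurements. Nothing measured here bears on why the step stays this small.

On these data alone, with only fluoro and nitro compared at this place, two groups cannot show a trend, so it remains open whether any group here would move the number beyond the scatter. An amine, a methoxy group or a carboxylic acid at the same place would test this, since each differs from fluoro and nitro in its atoms, and a step beyond the scatter from any of them would show that this place does affect the read-out.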